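A few compounds are considered here, and "the series" means these few. Any claim that something is new, unique, unknown or untested is made for them only; others in the source may bear on it.

In an ADME assay on BJ cells (Homo sapiens) for cytotoxicity, read by CellTiter-Glo and resazurin assay, with a stated time of 72 h (on this read-out higher numbers stand for an effect only at larger amounts of compound and lower numbers for an effect already at smaller amounts), compound 1 (`CCOC(=O)CCCCCOc1cccc(CN(C(=O)c2ccc(-c3cccc(N(C)C)c3)cc2)C(C)C)c1`) gives > 26000 nM as a limit of the assay, not a number. Compound 2 (`CCOC(=O)CCCCCOc1cccc(CN(C(=O)c2ccc(-c3cccc(CC(=O)O)c3)cc2)C(C)C)c1`) gives > 26000 nM and this, too, is only a limit. The picture so far is simply the limit of > 26000 nM in this assay, at which 2 of the 2 values shown sit, and nothing finer. Compound 3 (`CCOC(=O)CCCCCOc1cccc(CN(C(=O)c2ccc(Br)cc2)C(C)C)c1`) has bromo in place of 3-(carboxymethyl)phenyl on an aromatic carbon, para to a large group, as counted here: bromo in place of 3-(carboxymethyl)phenyl on an aromatic carbon is the whole difference. Among the measured compounds shown here, the one measured step, a step that the two limits leave unreadable from compound 1 to compound 2 on the outer ring, offers no size to build on. Compound 3 is therefore expected to show no step beyond the usual scatter and probably to stay at the same limit. The expected change is a step that the limit leaves unreadable from compound 2 to compound 3 in this estimate. The estimate for compound 3 is 30000 nM with an expected range from 15000 nM to 60000 nM if a number is obtained at all.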

Compound 3, half-maximal effective concentration: > 26000 nM
Compound 3: only a limit was reported; the forecaster's own chance of this, stated with the estimate: 85%; the middle value lies beyond the limit too.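

In this assay, among the compounds shown here, compound 3 also gives only a limit, so no step among compound 1, compound 2 and compound 3 can be read, and the picture stays: the limit of > 26000 nM in this assay, at which 3 of the 3 values shown sit. The compounds shown leave open at what amount, if any, each one affects these cells.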